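The compounds below may be only part of what the source reports. "The series", "measured", "known", "first", "only" and "open" are said of these compounds alone.

The study compares analogues that share one core and differ only in the group borne on a saturated ring carbon. Compound 1 `COc1cc(N2C(N)=C(C#N)C(c3ccc([N+](=O)[O-])cc3)C3=C2CC(C)(C)CC3=O)cc(OC)c1OC` carries 4-nitrophenyl there, and in a functional assay on Ehrlich cells (Mus musculus) for cytotoxicity, tested at 100 ug/mL (a higher number here means a stronger effect of the compound at the concentration tested, a lower number a weaker effect), compound 1 gives 80%. Compound 2 `COc1cc(N2C(N)=C(C#N)C(/C=C/c3ccccc3)C3=C2CC(C)(C)CC3=O)cc(OC)c1OC` carries 2-phenylethenyl instead, and in this assay compound 2 gives 40%. Going by the values given here, that is the lower of the two measured numbers, and its only neighbour is compound 1, separated by the large step of a number 40 percentage points lower from compound 1 to compound 2 (beyond the scatter), which lies beyond the scatter.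

Compound 3 `COc1cc(N2C(N)=C(C#N)C(c3c(OC)ccc4ccccc34)C3=C2CC(C)(C)CC3=O)cc(OC)c1OC` has not yet been measured. It differs from compound 2 in one place: 2-methoxynaphthalen-1-yl in place of 2-phenylethenyl on a saturated ring carbon. Among the compounds with values here, the single measured step that bears on this change is a number 40 percentage points lower from compound 1 to compound 2 (beyond the scatter), since it shows what happened when 2-phenylethenyl arrived in place of an aryl group. Returning to an aryl group, here 2-methoxynaphthalen-1-yl, is therefore expected to move the number upward again, though the new group is not the same as 4-nitrophenyl, so only part of that step is expected to be recovered. For compound 3 the expected step is a number 20 percentage points higher from compound 2 to compound 3 (beyond the scatter), and compound 3 is estimated to give 60% in this assay, within a range from 35% to 85%.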

Compound 3, a percentage reported as activity, at one concentration (the size of the read-out at that concentration, not a potency): 30%
Beside the measured number, compound 3's estimate is 30 percentage points above it; measured number outside the range, below it.
By their numbers in this assay, from the lowest: compounds 3 and 2 (each within the scatter of the next); then compound 1.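

In this assay the step of a number 10 percentage points lower from compound 2 to compound 3 (within the scatter) does not separate the two compounds, so on this saturated ring carbon an aromatic group in place of 2-phenylethenyl does not, in itself, bring back the number seen with 4-nitrophenyl. The large step of a number 50 percentage points lower from compound 1 to compound 3 (beyond the scatter) shows that 4-nitrophenyl stands apart from both other groups, even though those two differ from each other in their counts: 2-phenylethenyl has one six-membered aromatic ring and a double bond outside it, whereas 2-methoxynaphthalen-1-yl has two such rings and one hydrogen-bond acceptor. Why this single group stands apart is something no available evidence explains.

The compounds shown leave open whether the higher number belongs to the nitro group or to the single phenyl ring that carries it, a question that a plain phenyl, a 4-aminophenyl or a 4-carboxyphenyl on this carbon would address. They also leave open how a naphthalen-1-yl group without its methoxy group would read in this assay at this position.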